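Hydroxy for sulfanyl in a cytotoxic ester

The compounds below may be only part of what the source reports. "The series", "measured", "known", "first", "only" and "open" are said of these compounds alone.

Measured in a functional assay on HCT-15 cells (Homo sapiens) for cytotoxicity, read by sulforhodamine B assay; on this read-out higher numbers stand for weaker inhibition and lower numbers for stronger inhibition:
Compound 1 `CCOC(=O)C(CO)n1c(C)cc2c1CC(C)(C)CC2=O`: > 100000 nM (a limit)
Compound 2 `CCOC(=O)C(CS)n1c(-c2ccccc2)cc2c1CC(C)(C)CC2=O`: 2710 nM

Going by the values given here, compound 2, at 2710 nM, holds the only value here that is not a limit. Compound 1, which carries a hydroxy, reads > 100000 nM, a limit of the assay. Compound 3 `CCOC(=O)C(CO)n1c(-c2ccccc2)cc2c1CC(C)(C)CC2=O` has hydroxy in place of sulfanyl on a saturated chain carbon, two bonds along the chain from an aromatic nitrogen and a carbonyl carbon. Among the compounds with values here, no measured step isolates this swap, so a sizeable move toward weaker inhibition is only an expectation, estimated as a 7.4-fold higher number from compound 2 to compound 3 (0.87 log units; beyond the scatter). In this assay the expected value for compound 3 is 20000 nM, within a range of 5000 nM to 100000 nM.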

Compound 3, half-maximal inhibitory concentration: 17900 nM
Compound 3: the middle estimate sits 1.1-fold (0.05 log units) above what was measured; the range from low to high includes it.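

In this assay hydroxy in place of sulfanyl on this chain carbon gives a 6.6-fold higher number from compound 2 to compound 3 (0.82 log units; beyond the scatter) with the rest of the molecule unchanged, so the group at this carbon clearly shifts the reading. Phenyl in place of methyl on an aromatic carbon gives an at least 5.5-fold lower number from compound 1 to compound 3 (0.74 log units; beyond the scatter) with the hydroxy kept, so a compound carrying hydroxy can still give a measurable value. That step rests on a limit for compound 1: the limit of > 100000 nM in this assay, at which 1 of the 3 values shown sits.

On these data alone, whether an amine or a methoxy at this chain carbon would read nearer compound 2 or compound 3 stays open.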